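Propylamino Sulfonamide Analogue of a Weak Kinase Binder

The compounds below may be only part of what the source reports. "The series", "measured", "known", "first", "only" and "open" are said of these compounds alone.

Going by the values given here, compound 2 `CC1(C)CCN1S(=O)(=O)c1cncc(-c2ccn3nc(N)nc3c2)c1` gives 50100000 nM in an assay on isolated protein for inhibition of phosphatidylinositol 4,5-bisphosphate 3-kinase catalytic subunit beta isoform (Homo sapiens) (on this read-out lower numbers stand for stronger inhibition and higher numbers for weaker inhibition), the highest of the two numbers measured so far. Its nearest neighbour, compound 1 `CCN(CC)S(=O)(=O)c1cncc(-c2ccn3nc(N)nc3c2)c1`, gives 25100000 nM in this assay, and the step of a 2.0-fold higher number from compound 1 to compound 2 (0.30 log units; within the scatter) lies within the scatter, so the two cannot be ordered. Compound 3 `CCCNS(=O)(=O)c1cncc(-c2ccn3nc(N)nc3c2)c1` differs from compound 2 at the sulfonyl sulfur: propylamino in place of 2,2-dimethylazetidin-1-yl on a sulfonyl sulfur. Among the compounds with values here, the only measured step at this sulfonyl sulfur, a 2.0-fold higher number from compound 1 to compound 2 (0.30 log units; within the scatter), swapped one amine for another and moved nothing beyond the scatter. Within the data shown here, no measured step brings a hydrogen-bond donor into this place, so the propylamino group has no precedent among the measured compounds. The step expected from this change is a 1.4-fold lower number from compound 2 to compound 3 (0.16 log units; within the scatter), which is none beyond the scatter. Compound 3 is therefore expected to give about 35000000 nM in this assay, with a range from 8000000 nM to 150000000 nM.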

Compound 3, half-maximal inhibitory concentration: 31600000 nM
For compound 3 the middle estimate is 1.1-fold (0.04 log units) above the measured one; low and high end bracket the measured number.
By their numbers in this assay, from the lowest: compounds 1, 3 and 2 (each within the scatter of the next).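

Both a 1.6-fold lower number from compound 2 to compound 3 (0.20 log units; within the scatter) and a 1.3-fold higher number from compound 1 to compound 3 (0.10 log units; within the scatter) stay within the scatter in this assay, so compound 3 cannot be ordered against either neighbour. Propylamino is the first group at this sulfonyl sulfur to bring a hydrogen-bond donor, and that change, like the loss of the four-membered ring, produces no readable difference, so all three amines shown on this sulfur remain level within the scatter. No measurement here bears on the reason for this result.

The compounds shown leave open whether any group on this sulfonyl sulfur can move the number beyond the scatter, such as a plain amino group, a piperazine or a longer chain ending in a carboxylic acid. They also leave open whether the number depends on this sulfur at all or on the shared core.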